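Compound 1 to compound 3: expected clearance step

The compounds below may be only part of what the source reports. "The series", "measured", "known", "first", "only" and "open" are said of these compounds alone.

Measured in an in vitro ADME assay on microsomes from liver (Homo sapiens) for pharmacokinetics; a higher number here means faster removal of the compound, a lower number slower removal:
- compound 1 `Cc1ccc(S(=O)(=O)N2C=CNC(=O)[C@H]2CC(=O)NC2CCNc3ccccc32)cc1`: < 50 mL.min-1.g-1, a limit of the assay
- compound 2 `CC(=O)N1CCC(NC(=O)C[C@@H]2C(=O)NC=CN2S(=O)(=O)c2ccc(C)cc2)c2ccccc21`: 450 mL.min-1.g-1

Compound 1 stands at the limit of < 50 mL.min-1.g-1 in this assay, at which 1 of the 2 values shown sits, a limit and not a number. Compound 3 `Cc1ccc(S(=O)(=O)N2C=CNC(=O)[C@H]2CC(=O)NC2CCCCC2C)cc1` has not yet been measured. Its difference from compound 1 is a group of 7 heavy atoms (7 carbon; one six-membered non-aromatic ring of carbon only) in place of a group of 10 heavy atoms (9 carbon, 1 nitrogen; one six-membered non-aromatic ring with 1 hetero atom, one six-membered aromatic ring of carbon only), on an amide-type nitrogen.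

Among the compounds with values here, one measured step bears on this change: an at least 9.0-fold higher number from compound 1 to compound 2 (0.95 log units; beyond the scatter). It was made on the group that leaves here and lies beyond the scatter, so this assay does respond to changes in this group. The guide is indirect, as compound 3 carries no acetyl. A rise of lesser size than an at least 9.0-fold higher number from compound 1 to compound 2 (0.95 log units; beyond the scatter) is therefore expected, towards faster removal. The expected step is an at least 3.0-fold higher number from compound 1 to compound 3 (0.47 log units; beyond the scatter). For compound 3 the estimate is 150 mL.min-1.g-1, with an expected range of 50 mL.min-1.g-1 to 450 mL.min-1.g-1.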

Compound 3, intrinsic clearance in microsomes: 212 mL.min-1.g-1
Estimate against measurement, compound 3: 1.4-fold (0.15 log units) below; measured number inside the range.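

In this assay the change to 2-methylcyclohexyl on the amide-type nitrogen gives an at least 4.2-fold higher number from compound 1 to compound 3 (0.62 log units; beyond the scatter) and so shows that a rise at this position does not need an acetyl. Replacing the whole group, with its nitrogen and its aromatic ring, is also enough to produce a step beyond the scatter. The true size of this step remains unknown, as compound 1 stands at a limit and not at a number: the limit of < 50 mL.min-1.g-1 in this assay, at which 1 of the 3 values shown sits.

The compounds shown leave open whether the rise follows the loss of the nitrogen, the loss of the aromatic ring or the gain of the methyl, as this one step changes all of them at once. They also leave open how the read-out would respond to an amine or a carboxylic acid on the cyclohexyl ring.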